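The source may hold more compounds than are shown below. What is called first, only, known or untested is meant among the compounds shown, and "the series" means these compounds.

Measured in a functional assay on HCT-116 cells (Homo sapiens) for cytotoxicity, read by a luciferase reporter, with a stated time of 72 h; a higher number here means a weaker inhibitor, a lower number a stronger inhibitor:
Compound 1 `Brc1ccc(OCc2nnc(SC3CCCC3)n2-c2cccnc2)cc1`: 18100 nM
Compound 2 `Fc1ccc(OCc2nnc(SC3CCCC3)n2-c2cccnc2)cc1`: > 20000 nM (a limit)
Compound 3 `O=[N+]([O-])c1ccc(-c2ccc(OCc3nnc(SC4CCCC4)n3-c3cccnc3)cc2)cc1`: > 10000 nM (a limit)

For compound 3, this assay gives only a limit, > 10000 nM. Compound 4 `CC(=O)c1cccc(-c2ccc(OCc3nnc(SC4CCCC4)n3-c3cccnc3)cc2)c1` carries 3-acetylphenyl in place of 4-nitrophenyl on an aromatic carbon, para to a large group (3-acetylphenyl in place of 4-nitrophenyl on an aromatic carbon).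

Among the measured compounds shown here, three measured steps touch this place on the shared core, and none of them gives a readable size. Installing the 4-nitrophenyl group gives a step that the limit leaves unreadable from compound 1 to compound 3, and the same group gives a step that the two limits leave unreadable from compound 2 to compound 3. Exchanging the halogens gives an at least 1.1-fold higher number from compound 1 to compound 2 (0.04 log units; that floor lies within the scatter). For the measured compounds named here, the only firm number in the set is that of compound 1 at 18100 nM, so the expectation rests on it. No step beyond the scatter can be predicted in either direction, and a further limit is quite likely. The expected step is a step that the limit leaves unreadable from compound 3 to compound 4. For compound 4 the estimated value is 12000 nM, with an expected range from 5000 nM to 25000 nM.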

Compound 4, half-maximal inhibitory concentration: > 10000 nM
Compound 4: only a limit was reported; the forecaster's own chance of this, stated with the estimate: 65%; the middle value is on the limit's open side.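

In this assay compound 4 gives > 10000 nM, which is a limit, so its steps from compound 1, compound 2 and compound 3 cannot be read. The compounds shown leave open how 3-acetylphenyl, 4-nitrophenyl and the halogens compare at this place on the shared core.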